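The source may report more compounds than this note shows. Statements on the series, on what has been measured and on what is new or still open speak of the compounds shown alone.

Of the compounds shown here, two have been measured in an assay on microsomes from liver for inhibition of acyl-CoA desaturase 1 (Rattus norvegicus); on this read-out lower numbers stand for stronger inhibition and higher numbers for weaker inhibition. Compound 1, `Cc1ccccc1OC1CCN(c2ccc(-n3ccnc3)nn2)CC1`, gives 39 nM in this assay. Compound 2, `OCc1nnc(-c2ccc(N3CCC(Oc4ccccc4C(F)(F)F)CC3)nn2)s1`, gives 3.2 nM, the lowest of the two numbers; compound 1 stands well higher, and that gap lies beyond the usual scatter. Compound 3, `Cc1nnc(-c2ccc(N3CCC(Oc4ccccc4C(F)(F)F)CC3)nn2)s1`, has not yet been measured. It differs from compound 2 in one place: hydrogen in place of hydroxy on a saturated chain carbon bound to an aromatic carbon. Read one bond further out, the change is hydroxymethyl to methyl, the 5-(hydroxymethyl)-1,3,4-thiadiazol-2-yl group becoming 5-methyl-1,3,4-thiadiazol-2-yl. Among the compounds with values here, no measured pair shows this change, so its size is not known from the data; what leaves is one hydrogen-bond donor and one hydrogen-bond acceptor. The step is expected to be small, quite possibly none beyond the scatter, with no firm direction. Compound 3 is therefore estimated at 5 nM, with a likely range from 1.5 nM to 16 nM. The shift expected a 1.6-fold higher number from compound 2 to compound 3 (0.19 log units; within the scatter) is modest.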

Compound 3, half-maximal inhibitory concentration: 2.3 nM
For compound 3 the middle estimate is 2.2-fold (0.34 log units) above the measured one; measured number inside the range.
By their numbers in this assay, from the lowest: compounds 3 and 2 (each within the scatter of the next); then compound 1.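

In this assay, within the data shown here, the change from 5-(hydroxymethyl)-1,3,4-thiadiazol-2-yl to 5-methyl-1,3,4-thiadiazol-2-yl gives a 1.4-fold lower number from compound 2 to compound 3 (0.14 log units; within the scatter), the first measured pair for this change, and that step lies within the scatter. The hydroxy, and with it one hydrogen-bond donor and one hydrogen-bond acceptor, can therefore leave this saturated chain carbon bound to an aromatic carbon with no shift that can be told apart from repeat measurement. No available evidence offers an explanation for this result.

The compounds shown leave open whether an aminomethyl group, a carboxylic acid or a longer chain in place of hydroxymethyl would also stay within the scatter. On these data alone, whether hydroxymethyl and methyl would read alike on another core, such as the core of compound 1, also remains open.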